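Methyl against hydrogen on the ring nitrogen: cytotoxicity notes

The source may hold more compounds than are shown below. What is called first, only, known or untested is meant among the compounds shown, and "the series" means these compounds.

Compound 1 `Cn1c(/C=C/C(=O)c2ccccc2)cc(Br)c1Br`: in a functional assay on WRL68 cells (Homo sapiens) for cytotoxicity, read by MTT assay, with stated times of 6 h and 48 h (a lower number here means a stronger inhibitor, a higher number a weaker inhibitor), compound 1 gives >= 100000 nM, a limit of the assay.
Compound 2 `COc1ccc(OC)c(C(=O)/C=C/c2cc(Br)c(Br)n2C)c1`: in this assay compound 2 gives 3270 nM.
Compound 3 `O=C(/C=C/c1cc(Br)c(Br)[nH]1)c1ccccc1`: in this assay compound 3 gives >= 100000 nM, a limit of the assay.

Among the compounds with values here, compound 2 carries the only number here; the other two values are limits. The difference between the cores of compound 1 and compound 2 is not broken down here. From compound 1 to compound 3 the change is hydrogen in place of methyl on an aromatic nitrogen, and the step that the two limits leave unreadable from compound 1 to compound 3 cannot be read because of the limit of >= 100000 nM in this assay, at which 2 of the 3 values shown sit.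

Compound 4 `COc1ccc(OC)c(C(=O)/C=C/c2cc(Br)c(Br)[nH]2)c1` is the unmeasured partner of compound 2, differing by hydrogen in place of methyl on an aromatic nitrogen, the same change as from compound 1 to compound 3. That measured instance gives no readable size, so the expectation for compound 4 rests on compound 2 alone. For compound 4 the expected step is a 1.5-fold higher number from compound 2 to compound 4 (0.18 log units; within the scatter) from the value of compound 2 3270 nM. Compound 4 is estimated to give about 5000 nM, between 1500 nM and 30000 nM.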

Compound 4, half-maximal inhibitory concentration: 12300 nM
Beside the measured number, compound 4's estimate is 2.5-fold (0.39 log units) below it; the measured number falls inside the stated range.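

In this assay, hydrogen in place of methyl on the aromatic nitrogen gives a 3.8-fold higher number from compound 2 to compound 4 (0.58 log units; beyond the scatter), so on the core of compound 2 the compound carrying methyl has the lower number. Going by these compounds, the same change on the core of compound 1 cannot be read, and whether the step carries from one core to the other stays unknown, because both compounds of that pair stand at a limit of the assay: the limit of >= 100000 nM in this assay, at which 2 of the 4 values shown sit. This single readable instance fixes no general size for the change in this series and gives no cause for it.

The compounds shown leave open how a longer chain on the aromatic nitrogen, such as ethyl or propyl, would compare with methyl and hydrogen. They also leave open what an amine or a carboxylic acid at the end of such a chain would do.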